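A Trifluoromethyl Swap in a Narrow Series

The compounds below may be only part of what the source reports. "The series", "measured", "known", "first", "only" and "open" are said of these compounds alone.

In a functional assay on the whole organism (Cavia porcellus) with Rattus norvegicus as the target (on this read-out higher numbers stand for an effect only at larger amounts of compound and lower numbers for an effect already at smaller amounts), compound 1 `CC1=CS[C@@](O)(c2ccc(-c3ccccc3)cc2)c2noc(=O)n21` gives 378000000 nM, compound 2 `CC1=CS[C@@](O)(c2ccc([N+](=O)[O-])cc2)c2noc(=O)n21` gives 607000000 nM and compound 3 `CC1=CS[C@@](O)(c2cccc(C)c2)c2noc(=O)n21` gives 719000000 nM. Compound 3 therefore stands within the scatter of both other compounds. Compound 4 `CC1=CS[C@@](O)(c2cccc(C(F)(F)F)c2)c2noc(=O)n21` differs from it by trifluoromethyl in place of methyl on an aromatic carbon. Among the measured compounds shown here, only one measured step bears on this change, a 1.6-fold higher number from compound 1 to compound 2 (0.21 log units; within the scatter), which also exchanges a group on an aromatic carbon and stays within the scatter. No step beyond the scatter, in either direction, is therefore expected in this assay. The estimated step is a 1.2-fold lower number from compound 3 to compound 4 (0.08 log units; within the scatter). For compound 4 the expected value is 600000000 nM, with an estimated range of 300000000 nM to 1200000000 nM.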

Compound 4, half-maximal effective concentration: 461000000 nM
Beside the measured number, compound 4's estimate is 1.3-fold (0.11 log units) above it; low and high end bracket the measured number.
By their numbers in this assay, from the lowest: compounds 1, 4, 2 and 3 (each within the scatter of the next).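

In this assay trifluoromethyl in place of methyl on an aromatic carbon meta to a large group gives a 1.6-fold lower number from compound 3 to compound 4 (0.19 log units; within the scatter) and so leaves this position without a step beyond the scatter. Here, going from 1 heavy atom to 4 heavy atoms does not separate the two compounds in this read-out. Nothing measured accounts for this result. The compounds shown leave open whether an amine, a carboxylic acid or a longer chain at this position would give a step beyond the scatter. They also leave open whether any group here can do so.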